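Removing the nitrile: from compound 2 to compound 3

The compounds below may be only part of what the source reports. "The series", "measured", "known", "first", "only" and "open" are said of these compounds alone.

Two compounds share a core and differ only in one substituent on an outer phenyl ring. Compound 1 `Cc1cc(C)cc(-c2c(C)nn(-c3nc(-c4ccc(Cl)c(Cl)c4)c(SC(C)C)s3)c2C(=O)O)c1` carries two methyl groups there, and in a functional assay on BJAB cells (Homo sapiens) for antiproliferative activity, with a stated time of 4 days (on this read-out lower numbers stand for an effect already at smaller amounts and higher numbers for an effect only at larger amounts of compound), compound 1 gives 2700 nM. Compound 2 `Cc1cc(C#N)cc(-c2c(C)nn(-c3nc(-c4ccc(Cl)c(Cl)c4)c(SC(C)C)s3)c2C(=O)O)c1` has a cyano group in place of one methyl, and in this assay compound 2 gives 4800 nM. Of the two numbers, compound 2 holds the higher one, but the step of a 1.8-fold higher number from compound 1 to compound 2 (0.25 log units; within the scatter) lies within the scatter. Compound 3 `Cc1cccc(-c2c(C)nn(-c3nc(-c4ccc(Cl)c(Cl)c4)c(SC(C)C)s3)c2C(=O)O)c1` is compound 2 with the cyano group taken away: hydrogen in place of cyano on an aromatic carbon, so the 3-cyano-5-methylphenyl becomes 3-methylphenyl. Going by the values given here, the only step that bears on this is the methyl-to-cyano exchange, which did not move the number beyond the scatter. A removal of the same cyano is therefore expected to give a step of a 1.4-fold lower number from compound 2 to compound 3 (0.14 log units; within the scatter), with no clear direction. Compound 3 is thus expected to give about 3500 nM in this assay, in a range from 1500 nM to 8000 nM.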

Compound 3, half-maximal effective concentration: 17000 nM
Compound 3: the middle estimate sits 4.9-fold (0.69 log units) below what was measured; the whole stated range lies below it.
By their numbers in this assay, from the lowest: compounds 1 and 2 (each within the scatter of the next); then compound 3.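

In this assay, this aromatic carbon turns out to matter: with hydrogen there, the result is a 3.5-fold higher number from compound 2 to compound 3 (0.55 log units; beyond the scatter) and a 6.3-fold higher number from compound 1 to compound 3 (0.80 log units; beyond the scatter), and both steps lie beyond the scatter. Methyl and cyano could not be told apart at this carbon, yet replacing either one with hydrogen raises the number, so more compound is needed for the same effect; among these three compounds, having one of these two groups there counts for more than which of the two it is. Nothing available here explains this difference.

Going by these compounds, it remains open whether a chlorine atom, a methoxy group or a longer chain such as ethyl at this carbon would match methyl and cyano or fall closer to hydrogen. On these data alone, it is also open whether hydrogen would give a similar step if other parts of the shared core were changed.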